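This account rests on a few compounds, and the source may have more. Where it says the series, first, only, none or still open, it means among the compounds named here.

Measured so far:
Compound 1 `ClCc1ccccc1Cn1cnc2c(Cl)nc(Cl)nc21` gives 4260 nM in a functional assay on SK-MEL-5 cells (Homo sapiens) for cytotoxicity, read by sulforhodamine B assay, with a stated time of 48 h; on this read-out lower numbers stand for higher toxicity in this test and higher numbers for lower toxicity in this test.
Compound 2 `ClCc1cccc(Cn2cnc3nc(Cl)nc(Cl)c32)c1` gives 4890 nM in this assay.

Compound 1 has the lowest number of the two values shown in this assay; its nearest neighbour is compound 2, and the gap between the two values lies within the scatter, so no order between them can be read from these numbers. Going by the values given here, no step between two measured compounds that differ in one place is available for this pair of compounds.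

The unmeasured compound 3 `Nc1nc(Cl)c2ncn(Cc3ccccc3CCl)c2n1` is reached from compound 1 by a single change: amino in place of chloro on an aromatic carbon. Nothing measured in this series speaks to such a change, so the expected size of the step in this assay rests on the change alone and on the small spread seen so far. In this assay the expected step is a 1.3-fold higher number from compound 1 to compound 3 (0.11 log units; within the scatter), which is held to lie within the scatter, with only a slight lean toward a higher number. For compound 3 the estimate in this assay is 5500 nM, with a range from 2000 nM to 15000 nM.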

Compound 3, concentration lethal to 50% of the cells: 75900 nM
For compound 3 the middle estimate is 14-fold (1.14 log units) below the measured one, and the stated range ends below it.
By their numbers in this assay, from the lowest: compounds 1 and 2 (each within the scatter of the next); then compound 3.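

In this assay, going by these compounds alone, the position between two ring nitrogen atoms proves sensitive to substitution: amino in place of chloro on this aromatic carbon gives an 18-fold higher number from compound 1 to compound 3 (1.25 log units; beyond the scatter) and is the only step beyond the scatter so far. Within the data shown here, compounds 1 and 2 both carry chloro at this position, so their values could not show this sensitivity; compound 3 provides the first read-out of a change on the shared core itself, and a single heavy-atom exchange there is enough to produce a large step. The data at hand offer no measured basis for explaining the size of this step.

Still open, as far as these compounds go, is whether the step follows from the loss of chloro or from the entry of amino, a question that hydrogen, methoxy or a methylamino group at the same carbon would help to separate. Also open, from the compounds shown here alone, is whether amino in place of the other chloro group on the core, or the same exchange on compound 2, would give a step of similar size, since the present step rests on a single pair of compounds.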